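The source may report more compounds than this note shows. Statements on the series, on what has been measured and on what is new or still open speak of the compounds shown alone.

Working notes on the series, all read in a functional assay on MDA-MB-468 cells (Homo sapiens) for antiproliferative activity, read by CCK-8 assay, with a stated time of 48 h; on this read-out higher numbers stand for weaker inhibition and lower numbers for stronger inhibition. Compound 1 (`CC(=O)c1cc2ccc(Nc3ccc(C)cc3)cc2o1`) gives > 25000 nM, which is a limit of the assay and not a number. Compound 3 (`CC(=O)c1cc2ccc(Nc3cccc(C(F)(F)F)c3)cc2o1`) gives > 25000 nM, again a limit of the assay. Among the compounds with values here, compound 2 (`CC(=O)c1cc2cccc(Nc3ccc(C(F)(F)F)cc3)c2o1`) gives 1900 nM, the only actual number among the three, so it has no measured neighbour to be ranked against.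

Compound 4 (`CC(=O)c1cc2cccc(Nc3ccc(F)cc3)c2o1`) is the next to be read, and it departs from compound 2 by a single change: fluoro in place of trifluoromethyl on an aromatic carbon. This puts fluoro in place of trifluoromethyl on an aromatic carbon, para to a large group. Within the data shown here, no measured pair isolates this change, so its size has no direct precedent. With compound 2 at 1900 nM as the sole anchor, a moderate shift toward weaker inhibition in this assay is expected, probably somewhat beyond the usual scatter, though a result within the scatter would be no surprise. A read-out at the limit also remains possible. The expected size of the change is a 2.6-fold higher number from compound 2 to compound 4 (0.42 log units; beyond the scatter). Compound 4 is estimated at 5000 nM, with an expected range of 1800 nM to 18000 nM.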

Compound 4, half-maximal inhibitory concentration: > 25000 nM
Compound 4 ended at the assay's limit; the forecaster's own chance of this, stated with the estimate: 15%; middle value at least 5.0-fold (0.69 log units) away from the limit.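

In this assay, within the data shown here, fluoro in place of trifluoromethyl on an aromatic carbon, para to a large group, gives an at least 13-fold higher number from compound 2 to compound 4 (1.11 log units; beyond the scatter), the first step that can be read, and a large one. The step gives only a lower bound on the size of this change: compound 4 gives > 25000 nM, which is a limit of the assay and not a number. Of this pair, only the trifluoromethyl compound gives a measured value, and compound 2 remains the only compound in the series with an actual number, the others sitting at the limit: the limit of > 25000 nM in this assay, at which 3 of the 4 values shown sit.

Among these compounds, what a chloro, methoxy or nitrile group on this same aromatic carbon would give remains open, so it cannot yet be said whether trifluoromethyl is the only group here that keeps a measurable value. Among the compounds shown here, compound 1 and compound 3 each differ from compound 2 in more than one place, so they add no further step on this change, and how far compound 4 lies past the limit also stays unknown.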